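The source may report more compounds than this note shows. Statements on the series, on what has been measured and on what is new or still open speak of the compounds shown alone.

In an ADME assay on a cell-free system (plasma, Homo sapiens) for metabolic stability, read by LC-MS (a lower number here means that the compound disappears faster, a higher number that the compound lasts longer), the measured compounds stand as follows:
Compound 1 `NCc1ccc(C(=O)Nc2ccncc2)cc1-c1cccc(C(=O)OCc2ccccc2)c1` gives 1.07 h
Compound 2 `NCc1ccc(C(=O)Nc2ccncc2F)cc1-c1cccc(C(=O)OCC2CCCC2)c1` gives 0.283 h

Compound 1 holds the higher of these two numbers, and compound 2 lies below it by more than the scatter. Compound 3 `CCCOC(=O)c1cccc(-c2cc(C(=O)Nc3ccncc3)ccc2CN)c1` is not yet measured. It differs from compound 1 as follows (ethyl in place of phenyl on a saturated chain carbon bound to an oxygen next to a carbonyl group): ethyl in place of phenyl on a saturated chain carbon bound to an oxygen next to a carbonyl group, so benzyloxycarbonyl becomes propoxycarbonyl. Among the measured compounds shown here, no measured pair shows this change. Compound 2 at 0.283 h also lacks benzyloxycarbonyl, but it differs elsewhere too, so it is only a weak guide. A small drop within the scatter is expected (a 1.8-fold lower number from compound 1 to compound 3 (0.25 log units; within the scatter)). The estimated half-life of compound 3 is 0.6 h with an expected range from 0.25 h to 1.5 h in this assay terms.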

Compound 3, half-life: 0.3 h
Compound 3: middle estimate off by 2.0-fold (0.30 log units), on the high side, within the range that was stated.
By their numbers in this assay, from the lowest: compounds 2 and 3 (each within the scatter of the next); then compound 1.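

In this assay, ethyl in place of phenyl on a saturated chain carbon bound to an oxygen next to a carbonyl group gives a 3.6-fold lower number from compound 1 to compound 3 (0.55 log units; beyond the scatter) in the half-life. This single-place comparison, which compound 2 could not give, shows that the group at this position matters: benzyloxycarbonyl lasts longer than propoxycarbonyl. No measurement here accounts for the step.

Still open, from the compounds shown here alone, is whether the ring itself matters or simply the size of the group. Cyclohexyl or a longer chain such as butyl at this position could help separate the two.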